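Changing the sulfur-linked chain: compound 2 to compound 3

A few compounds are considered here, and "the series" means these few. Any claim that something is new, unique, unknown or untested is made for them only; others in the source may bear on it.

compound 1 `CC(C)c1n[nH]c2c(NCc3ccc(-c4ccccn4)cc3)nc(SCC(O)CN)nc12`: 55 nM
compound 2 `CC(C)c1n[nH]c2c(NCc3ccc(-c4ccccn4)cc3)nc(SCCNC(=N)N)nc12`: 390 nM

Within the data shown here, in a functional assay on HT cells (Homo sapiens) for antiproliferative activity, read by fluorescence, with a stated time of 72 h (a higher number here means a weaker inhibitor of growth, a lower number a stronger inhibitor of growth), compound 2 gives 390 nM, the higher of the two numbers so far. The next structure is compound 3 `CC(C)c1n[nH]c2c(NCc3ccc(-c4ccccn4)cc3)nc(SCC(N)=O)nc12`, with the change (a group of 3 heavy atoms (1 carbon, 1 nitrogen, 1 oxygen; no ring) in place of a group of 5 heavy atoms (2 carbon, 3 nitrogen; no ring), on a saturated chain carbon bound to a sulfur). Carbamoyl thus enters on a saturated chain carbon bound to a sulfur. Among the measured compounds shown here, one measured step bears on this place: a 7.1-fold higher number from compound 1 to compound 2 (0.85 log units; beyond the scatter). That step is modest but beyond the scatter, and it shows that a change here can move the number. Neither measured compound carries carbamoyl, so the step gives no direction for this group. A step no larger than that one is expected in this assay, most likely none beyond the scatter. The estimated step is a 1.3-fold lower number from compound 2 to compound 3 (0.11 log units; within the scatter). For compound 3 the expected value is 300 nM, with an estimated range from 90 nM to 1000 nM.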

Compound 3, concentration for 50% growth inhibition: 192 nM
For compound 3 the middle estimate is 1.6-fold (0.19 log units) above the measured one; low and high end bracket the measured number.
By their numbers in this assay, from the lowest: compound 1; then compound 3; then compound 2.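

Carbamoyl on the saturated chain carbon bound to a sulfur gives a modest gain over the larger group in compound 2, with a 2.0-fold lower number from compound 2 to compound 3 (0.31 log units; beyond the scatter) in this assay. It still falls short of 2-amino-1-hydroxyethyl, with a 3.5-fold higher number from compound 1 to compound 3 (0.54 log units; beyond the scatter), so compound 3 sits between the two earlier compounds, and both steps are beyond the scatter. The order does not follow group size: carbamoyl is the smallest of the three groups, yet compound 1, with the group of intermediate size, gives the lowest number.

Still open, on these data alone, is whether the amine or the hydroxyl of 2-amino-1-hydroxyethyl accounts for the lower number of compound 1. Also open, as far as these compounds go, is where a carboxylic acid or a longer chain carrying a terminal amine would fall at this place. No measurement shown here bears on the reason for these differences.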